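From Cyclohexyl to 4-Methoxyphenyl on a Carbonyl Carbon

This account rests on a few compounds, and the source may have more. Where it says the series, first, only, none or still open, it means among the compounds named here.

- compound 1 `O=C(OC1CCC(CN2CCN(c3cc(=O)c4cc(C(F)(F)F)cc([N+](=O)[O-])c4s3)CC2)CC1)c1ccco1`: 1%
- compound 2 `O=C(OC1CCC(CN2CCN(c3cc(=O)c4cc(C(F)(F)F)cc([N+](=O)[O-])c4s3)CC2)CC1)c1ccc(C(F)(F)F)cc1`: 5.2%
- compound 3 `O=C(OC1CCC(CN2CCN(c3cc(=O)c4cc(C(F)(F)F)cc([N+](=O)[O-])c4s3)CC2)CC1)C1CCCCC1`: 2.8%

These three compounds share a core and differ only in the group on a carbonyl carbon. All were tested in an ADME assay on cells (Hepatocyte, Homo sapiens) for metabolic stability, with a stated time of 30 min; on this read-out higher numbers stand for a more stable compound and lower numbers for a less stable compound. In this assay compound 3 gives 2.8%, and it cannot be clearly separated from either of the other two. The steps that show this are a number 1.8 percentage points higher from compound 1 to compound 3 (within the scatter) and a number 2.4 percentage points lower from compound 2 to compound 3 (within the scatter).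

Compound 4 `COc1ccc(C(=O)OC2CCC(CN3CCN(c4cc(=O)c5cc(C(F)(F)F)cc([N+](=O)[O-])c5s4)CC3)CC2)cc1` has not yet been measured. Its difference from compound 3 is 4-methoxyphenyl in place of cyclohexyl on a carbonyl carbon. In words, this is 4-methoxyphenyl in place of cyclohexyl on a carbonyl carbon.

Among the compounds with values here, no measured compound carries this exact group. The nearest comparison is compound 2, with its 4-(trifluoromethyl)phenyl group, at 5.2%. The remaining swap at this place is a number 4.2 percentage points higher from compound 1 to compound 2 (within the scatter). All three measured swaps stay within the scatter, so no step beyond the scatter is expected here, although three compounds are a thin basis. The expected change is a number 1.2 percentage points higher from compound 3 to compound 4 (within the scatter).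

Compound 4 is estimated at 4%, with an expected range from 1% to 12%.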

Compound 4, percent of the compound remaining: 12.2%
Compound 4: middle estimate off by 8.2 percentage points, on the low side, outside the stated range (above it).
By their numbers in this assay, from the lowest: compounds 1, 3, 2 and 4 (each within the scatter of the next, the first and the last beyond it).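

Within the data shown here, at this place on the carbonyl carbon, the earlier swaps all stayed within the scatter, whereas 4-methoxyphenyl gives the first step beyond it in this assay: a number 11.2 percentage points higher from compound 1 to compound 4 (beyond the scatter). The other two comparisons do not separate so clearly, with a number 9.4 percentage points higher from compound 3 to compound 4 (within the scatter) for the swap from cyclohexyl and a number 7 percentage points higher from compound 2 to compound 4 (within the scatter) for methoxy in place of trifluoromethyl on an aromatic carbon. The group on this carbonyl carbon can therefore shift the read-out measurably, but the shift is firm only against the furan-2-yl group, and even compound 4 keeps just 12.2% of the compound in this assay.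

Nothing available here bears on why the 4-methoxyphenyl compound sits apart from the furan-2-yl compound. Still open, going by these compounds, is whether this step belongs to the methoxy group or to the phenyl ring carrying it and the furan-2-yl group's absence, a question that a plain phenyl, a 4-hydroxyphenyl or a 4-aminophenyl group on the same carbonyl carbon would help to settle.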